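FAAH inhibitors: swapping methyl for trifluoromethyl on the pyridine

The source may report more compounds than this note shows. Statements on the series, on what has been measured and on what is new or still open speak of the compounds shown alone.

Measured so far:
compound 1 `O=C(CCCCCCc1ccccc1)c1ncc(-c2ccc(F)cc2)o1` gives 62 nM
compound 2 `Cc1ccnc(-c2cnc(C(=O)CCCCCCc3ccccc3)o2)c1` gives 0.6 nM

In an assay (Rattus norvegicus) for inhibition of Fatty-acid amide hydrolase 1 (Homo sapiens) (a lower number here means a stronger inhibitor, a higher number a weaker inhibitor), compound 2 holds the lowest of the two numbers measured; its nearest neighbour is compound 1, and the step of a 100-fold lower number from compound 1 to compound 2 (2.01 log units; beyond the scatter) separates them. Compound 3 `O=C(CCCCCCc1ccccc1)c1ncc(-c2cc(C(F)(F)F)ccn2)o1` has not yet been measured. It differs from compound 2 in one place: trifluoromethyl in place of methyl on an aromatic carbon. Going by the values given here, no measured step bears directly on this exchange; the only step seen, from compound 1 to compound 2, concerns the whole aromatic ring rather than a substituent on it, and it was large. With nothing to show what this substituent change does, the expectation for compound 3 is a step of modest size, a 2.5-fold higher number from compound 2 to compound 3 (0.40 log units; beyond the scatter), towards a somewhat higher number. Compound 3 is therefore estimated at 1.5 nM, with a range from 0.3 nM to 8 nM.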

Compound 3, inhibition constant: 3.5 nM
Estimate against measurement, compound 3: 2.3-fold (0.37 log units) below; measured number inside the range.
By their numbers in this assay, from the lowest: compound 2; then compound 3; then compound 1.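

In this assay, the carbon opposite the ring nitrogen and meta to a large group now has a substituent exchange of its own: trifluoromethyl in place of methyl gives a 5.8-fold higher number from compound 2 to compound 3 (0.77 log units; beyond the scatter), a modest step but one beyond the scatter. This position therefore responds to the exchange, though far less than the earlier replacement of the whole aromatic ring, a 100-fold lower number from compound 1 to compound 2 (2.01 log units; beyond the scatter), and compound 3 still gives 3.5 nM with the larger group in place. Nothing available accounts for the direction or size of this step.

The compounds shown leave open how a chlorine atom, a methoxy group or an amine on this carbon would compare with methyl and trifluoromethyl. They also leave open whether this exchange would give a similar step on a compound with a shorter chain.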